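The source may hold more compounds than are shown below. What is called first, only, known or untested is meant among the compounds shown, and "the series" means these compounds.

Of the compounds shown here, two have been measured in an assay on HEK293 cells for inhibition of acid ceramidase (Homo sapiens), read by fluorescence, with stated times of 10 min and 3 h; on this read-out lower numbers stand for stronger inhibition and higher numbers for weaker inhibition. Compound 1, `O=C(NCCCCc1ccccc1)n1c(=O)oc2cc(C3CCCCC3)ccc21`, gives 89 nM in this assay. Compound 2, `CCOCCNC(=O)n1c(=O)oc2cc(C3CCN(C)CC3)ccc21`, gives 1050 nM, the highest of the two numbers, standing a long way above compound 1, well beyond the usual scatter. Compound 1 and compound 2 differ from each other in more than one place, so no single change can be tied to that gap.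

Compound 3, `CN1CCC(c2ccc3c(c2)oc(=O)n3C(=O)NCCCCc2ccccc2)CC1`, has not yet been measured. It differs from compound 2 in one place only: phenethyl in place of ethoxy on a saturated chain carbon, two bonds along the chain from an amide-type nitrogen. In this assay, going by the values given here, the chain entering in compound 3 is the same one carried by compound 1, whose value of 89 nM is the lower of the two known numbers. Among the compounds with values here, no measured pair isolates this change, so the expectation rests on that single comparison. Compound 3 is expected to move downward from compound 2, by about a 3.5-fold lower number from compound 2 to compound 3 (0.54 log units; beyond the scatter). The estimated value of compound 3 is 300 nM, with a range from 100 nM to 900 nM.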

Compound 3, half-maximal inhibitory concentration: 129 nM
Beside the measured number, compound 3's estimate is 2.3-fold (0.37 log units) above it; the measured number falls inside the stated range.
By their numbers in this assay, from the lowest: compounds 1 and 3 (each within the scatter of the next); then compound 2.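

In this assay, phenethyl in place of ethoxy, on a saturated chain carbon two bonds along the chain from an amide-type nitrogen, gives an 8.1-fold lower number from compound 2 to compound 3 (0.91 log units; beyond the scatter), which shows that this chain position can change the read-out substantially. By contrast, 1-methylpiperidin-4-yl in place of cyclohexyl on an aromatic carbon gives a 1.4-fold higher number from compound 1 to compound 3 (0.16 log units; within the scatter), so this swap has no readable effect when the 4-phenylbutyl chain is present. Of these two changes, only the chain change moves the number beyond the scatter.

Nothing available explains either step. From the compounds shown here alone, it remains open whether the gain needs the aromatic ring or only the chain length, which a 4-cyclohexylbutyl chain or a shorter 2-phenylethyl chain could test, and whether the ring swap would also leave the number unchanged with the 2-ethoxyethyl chain.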